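Replacing the aminothiophene ketone with an aminomethylpyrimidine ketone

The source may report more compounds than this note shows. Statements on the series, on what has been measured and on what is new or still open speak of the compounds shown alone.

Measured compounds:
Compound 1 `COc1ccc(C(=O)/C=C/c2nc3ccccc3cc2-c2ccc(OC)cc2)cc1` gives 6420 nM in a functional assay on NCI-H1299 cells (Homo sapiens) for antiproliferative activity, read by XTT assay, with a stated time of 72 h; a lower number here means a stronger inhibitor, a higher number a weaker inhibitor.
Compound 2 `COc1ccc(-c2cc3ccccc3nc2/C=C/C(=O)c2sccc2N)cc1` gives > 10000 nM in this assay, which is a limit of the assay rather than a number.

Among the compounds with values here, compound 2 therefore stands only as a limit in this assay; it is the one of the two values that sits at the limit of > 10000 nM in this assay, at which 1 of the 2 values shown sits. Within the data shown here, the single measured step, an at least 1.5-fold higher number from compound 1 to compound 2 (0.19 log units; that floor lies within the scatter), replaced 4-methoxyphenyl on the carbonyl carbon with 3-aminothiophen-2-yl and left compound 2 at that limit, so the true size of that step is unknown.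

Compound 3 `COc1ccc(-c2cc3ccccc3nc2/C=C/C(=O)c2cnc(N)nc2C)cc1` differs from compound 2 in that (2-amino-4-methylpyrimidin-5-yl in place of 3-aminothiophen-2-yl on a carbonyl carbon). Among the measured compounds shown here, no measured step changes a group on this carbonyl carbon between two numbered values, so the only guide is that compound 2 already sits at the limit. Compound 3 is therefore expected to remain weak, with the step from compound 2 estimated as a step that the limit leaves unreadable from compound 2 to compound 3, in no firm direction. The estimate for compound 3 in this assay is 15000 nM, with a range from 4000 nM to 50000 nM, and a real chance that only a limit is reported again.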

Compound 3, half-maximal inhibitory concentration: > 10000 nM
Compound 3 ended at the assay's limit; the forecaster's own chance of this, stated with the estimate: 60%; the middle value is on the limit's open side.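

At this carbonyl carbon, 2-amino-4-methylpyrimidin-5-yl, a six-membered aromatic ring, also gives no number in this assay, so reaching a limit of the assay is not confined to the five-membered 3-aminothiophen-2-yl: the limit of > 10000 nM in this assay, at which 2 of the 3 values shown sit.

Replacing 4-methoxyphenyl with 2-amino-4-methylpyrimidin-5-yl gives an at least 1.5-fold higher number from compound 1 to compound 3 (0.19 log units; that floor lies within the scatter), so this change sets only a floor and does not establish a real loss. The step between the two limits cannot be read, which means the two amino-bearing groups cannot be ranked against each other.

The compounds shown leave open how far the true values of compound 2 and compound 3 lie beyond the limit, and so whether either group is much worse than 4-methoxyphenyl or hardly different from it. They also leave open whether a 4-aminophenyl or a plain phenyl on this carbonyl carbon would return a number that can be read, which would help separate the effect of the amino group from that of the ring carrying it.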